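Swapping a Dichlorobenzyl Thioether for a Propylsulfonyl Group

A few compounds are considered here, and "the series" means these few. Any claim that something is new, unique, unknown or untested is made for them only; others in the source may bear on it.

Compound 1 `CSc1nnc(COc2cc(C)c3c(C)cc(=O)oc3c2)o1`: in a functional assay on MCF7 cells (Homo sapiens) for antiproliferative activity, read by MTT assay, with a stated time of 24 h (a lower number here means a stronger inhibitor, a higher number a weaker inhibitor), compound 1 gives > 100000 nM, which is a limit of the assay rather than a number.
Compound 2 `CCCSc1nnc(COc2cc(C)c3c(C)cc(=O)oc3c2)o1`: in this assay compound 2 gives > 100000 nM, again only a limit.
Compound 3 `Cc1cc(OCc2nnc(SCc3ccc(Cl)cc3Cl)o2)cc2oc(=O)cc(C)c12`: in this assay compound 3 gives < 5000 nM, also a limit.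

So compound 3 stands at the limit of < 5000 nM in this assay, at which 1 of the 3 values shown sits. Compounds 1 and 2 share (the limit of > 100000 nM in this assay, at which 2 of the 3 values shown sit). Compound 4 `CCCS(=O)(=O)c1nnc(COc2cc(C)c3c(C)cc(=O)oc3c2)o1` differs from compound 3 by propylsulfonyl in place of (2,4-dichlorobenzyl)sulfanyl on an aromatic carbon. Among the compounds with values here, the one measured step that bears on this is an at least 20-fold lower number from compound 2 to compound 3 (1.30 log units; beyond the scatter), where the dichlorobenzyl group came in for a propyl chain; compound 4 reverses that exchange, though with a sulfonyl rather than the sulfanyl of compound 2, a change no measured pair covers. Compound 4 is therefore expected to be a markedly weaker inhibitor, with a step of an at least 20-fold higher number from compound 3 to compound 4 (1.30 log units; beyond the scatter). The estimate for compound 4 is 100000 nM, in a range from 20000 nM to 300000 nM.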

Compound 4, half-maximal inhibitory concentration: > 100000 nM
Compound 4 gave a limit, no number; the forecaster's own chance of this, stated with the estimate: 70%; the middle value lies on the limit itself.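

In this assay, the change at this aromatic carbon gives an at least 20-fold higher number from compound 3 to compound 4 (1.30 log units; beyond the scatter), so the propylsulfonyl group does not make up for the loss of the (2,4-dichlorobenzyl)sulfanyl group. Compound 4 gives only a limit, the same one as compound 1 and compound 2: the limit of > 100000 nM in this assay, at which 3 of the 4 values shown sit. The steps from compound 1 and compound 2 to compound 4 cannot be read, and so the sulfanyl and sulfonyl forms of the propyl compounds cannot be ranked. Still open, going by these compounds, is whether a plain benzylsulfanyl group, without its two chlorines, would do as well as the dichlorobenzyl group. A (2,4-dichlorobenzyl)sulfonyl group is open too.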